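Fluoro to methoxy on the aromatic carbon: working notes

The compounds below may be only part of what the source reports. "The series", "measured", "known", "first", "only" and "open" are said of these compounds alone.

Measured so far in a functional assay on the whole organism (strain Kunming) with Mus musculus as the target, in the formalin test, with a stated time of 0.5 h; a lower number here means that less compound is needed, a higher number that more compound is needed for the effect
- compound 1 `COc1cc(OC)c(OC)cc1/C=C/COC(=O)/C=C/c1ccc(Br)cc1` gives 243 umol/kg
- compound 2 `COc1cc(OC)c(OC)cc1/C=C/COC(=O)/C=C/c1ccc(F)cc1` gives 117 umol/kg

Within the data shown here, compound 2 holds the lower of only two numbers. Compound 3 `COc1ccc(/C=C/C(=O)OC/C=C/c2cc(OC)c(OC)cc2OC)cc1` differs from it by methoxy in place of fluoro on an aromatic carbon, para to a large group. Among the measured compounds shown here, one measured step bears on this place: a 2.1-fold lower number from compound 1 to compound 2 (0.32 log units; beyond the scatter), fluoro in place of bromo, modest but beyond the scatter. For the measured compounds named here, no measured compound carries methoxy here, so direction is poorly fixed. A modest step towards a higher number is expected in this assay, the expected step being a 1.4-fold higher number from compound 2 to compound 3 (0.14 log units; within the scatter). For compound 3 the estimate is 160 umol/kg, with an expected range of 60 umol/kg to 400 umol/kg.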

Compound 3, dose for half-maximal effect: 317 umol/kg
Beside the measured number, compound 3's estimate is 2.0-fold (0.30 log units) below it; measured number inside the range.
By their numbers in this assay, from the lowest: compound 2; then compounds 1 and 3 (each within the scatter of the next).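

In this assay, the fluoro advantage does not extend to methoxy at this place: a 2.7-fold higher number from compound 2 to compound 3 (0.43 log units; beyond the scatter), a modest step beyond the scatter, leaves the 4-fluorophenyl compound alone at the low end. Methoxy and bromo are not separated here, with a 1.3-fold higher number from compound 1 to compound 3 (0.12 log units; within the scatter), within the scatter. No evidence on the compounds accounts for this order.

Going by these compounds, whether an amine or a carboxylic acid at this place would sit nearer compound 2 or nearer compound 3 remains open. So does whether the fluoro advantage would persist with a longer chain elsewhere on the shared core.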